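The compounds below may be only part of what the source reports. "The series", "measured", "known", "first", "only" and "open" are said of these compounds alone.

Compound 1 `CCOc1ccccc1-c1ccc(-c2nc3cnccc3c(N[C@H](CC)C(=O)N(C)C)c2C#N)cc1` stands highest of the two compounds measured in a physicochemical assay for lipophilicity, read by HPLC, at pH 7.5; on this read-out higher numbers stand for higher lipophilicity and lower numbers for lower lipophilicity: compound 1 gives 3.7, while compound 2 `CCOc1ccccc1-c1ccc(-c2nc(NC(C)C(=O)O)c3ccncc3n2)cc1` gives 2.1, a gap beyond the usual scatter. Compound 3 `CCOc1ccccc1-c1ccc(-c2nc3cnccc3c(N[C@H](CC)C(N)=O)c2C#N)cc1` differs from compound 1 at one place: amino in place of dimethylamino on a carbonyl carbon. Among the compounds with values here, no measured pair shows this exact change, so the expectation rests on the structures alone. With dimethylamino leaving and amino entering, compound 3 is expected to sit lower than compound 1 in this assay by a moderate step, a number 0.70 log units lower from compound 1 to compound 3 (beyond the scatter), beyond the scatter. Compound 3 is therefore estimated at 3, within 2.5 to 3.5.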

Compound 3, distribution coefficient: 3
Beside the measured number, compound 3's estimate shows no gap at the digits printed; the measured number falls inside the stated range.
By their numbers in this assay, from the lowest: compound 2; then compound 3; then compound 1.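

Within the data shown here, with a number 0.70 log units lower from compound 1 to compound 3 (beyond the scatter) in this assay, this is the first step that can be read at a single place. Compound 1 and compound 2 differ in more than one place. It shows that the read-out responds to the group on this carbonyl carbon, and that trading dimethylamino for amino moves it by a modest step beyond the scatter. Nothing at hand explains this step. Still open, on these data alone, is where methylamino on this carbonyl carbon would fall relative to compound 1 and compound 3. Also open, as far as these compounds go, is whether a longer chain on the amide nitrogen would extend the same trend.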